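Enlarging the group on sulfur in compound 3

The source may report more compounds than this note shows. Statements on the series, on what has been measured and on what is new or still open speak of the compounds shown alone.

In a functional assay on MGC-803 cells (Homo sapiens) for inhibition, read by MTT assay, with a stated time of 72 h (a lower number here means a stronger inhibitor, a higher number a weaker inhibitor), compound 1 `FC(F)(F)c1ccc(CSc2nc(N3CCNCC3)cc(C(F)(F)F)n2)cc1` gives 5870 nM and compound 2 `CN1CCN(c2cc(C(F)(F)F)nc(SCc3ccc(C(F)(F)F)cc3)n2)CC1` gives 15800 nM. Compound 3 `FC(F)(F)c1ccc(CSc2nc(Sc3ccccn3)cc(C(F)(F)F)n2)cc1` gives > 50000 nM, which is a limit of this assay and not a number. Compound 4 `FC(F)(F)c1ccc(CSc2nc(Sc3ncc(-c4ccncc4)s3)cc(C(F)(F)F)n2)cc1` has 5-(pyridin-4-yl)-1,3-thiazol-2-yl in place of pyridin-2-yl on a sulfur. For the measured compounds named here, no measured step changes the group on that sulfur. The nearest evidence is two steps that introduce the (pyridin-2-yl)sulfanyl group: an at least 8.5-fold higher number from compound 1 to compound 3 (0.93 log units; beyond the scatter) and an at least 3.1-fold higher number from compound 2 to compound 3 (0.50 log units; beyond the scatter). The step of a 2.7-fold higher number from compound 1 to compound 2 (0.43 log units; beyond the scatter) concerns an amine nitrogen and does not bear on this change. A modest move towards a lower number is expected in this assay. The expected step is an at least 2.0-fold lower number from compound 3 to compound 4 (0.30 log units; that floor lies within the scatter). Compound 4 is estimated at 25000 nM, with an expected range of 7000 nM to 60000 nM.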

Compound 4, half-maximal inhibitory concentration: 5770 nM
Estimate against measurement, compound 4: 4.3-fold (0.64 log units) above; the whole stated range lies above it.
By their numbers in this assay, from the lowest: compounds 4 and 1 (each within the scatter of the next); then compound 2. At a limit, above all of these: compound 3.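

In this assay, the group on this sulfur proves open to change: 5-(pyridin-4-yl)-1,3-thiazol-2-yl in place of pyridin-2-yl gives an at least 8.6-fold lower number from compound 3 to compound 4 (0.93 log units; beyond the scatter). Compound 1 gives 5870 nM and compound 4 gives 5770 nM, values within the scatter of each other, so a sulfur-linked group can match piperazin-1-yl here. The full size of the step cannot be read because the value of compound 3 is a limit and not a number: the limit of > 50000 nM in this assay, at which 1 of the 4 values shown sits.

The compounds shown do not separate the contribution of the 1,3-thiazol-2-yl ring from that of its pyridin-4-yl group. Going by these compounds, whether phenyl, a primary amine or a carboxylic acid could replace that pyridin-4-yl group remains open.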